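The compounds below may be only part of what the source reports. "The series", "measured", "known", "first", "only" and "open" are said of these compounds alone.

In a functional assay on MDA-MB-231 cells (Homo sapiens) for antiproliferative activity, read by MTT assay, with a stated time of 72 h (on this read-out higher numbers stand for weaker inhibition and lower numbers for stronger inhibition), compound 1 `CC1=CCC2C(CC[C@@]2(C)O)C(C)(C)C1CC[C@@H]1[C@@]2(C)CCC(=O)C(C)(C)O[C@@H]2CC[C@]1(C)O` returns only the assay limit, > 50000 nM. Compound 2 `CC1=CC[C@H]2[C@H](CC[C@]2(C)O)C(C)(C)[C@@H]1CC[C@H]1[C@]2(C)CC[C@H](OC(=O)CCC(=O)O)C(C)(C)O[C@H]2CC[C@@]1(C)O` gives 27900 nM in this assay. Within the data shown here, compound 2 thus stands as the one numeric value in the pair, while compound 1 sits at the limit of > 50000 nM in this assay, at which 1 of the 2 values shown sits. Compound 3 `CC1=CC[C@H]2[C@H](CC[C@]2(C)O)C(C)(C)[C@@H]1CC[C@H]1[C@]2(C)CC[C@H](OC(=O)c3ccco3)C(C)(C)O[C@H]2CC[C@@]1(C)O` keeps the core of compound 2 and differs at one point: furan-2-yl in place of 2-carboxyethyl on a carbonyl carbon. Among the measured compounds shown here, no measured step covers this change, so the expectation rests on compound 2 alone. A modest gain is expected, a 1.9-fold lower number from compound 2 to compound 3 (0.27 log units; within the scatter), though not assured beyond the scatter. Compound 3 is estimated at 15000 nM, within a range from 4000 nM to 50000 nM.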

Compound 3, half-maximal inhibitory concentration: 14000 nM
Compound 3: the middle estimate sits 1.1-fold (0.03 log units) above what was measured; the range from low to high includes it.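

In this assay, among these compounds, the exchange at this carbonyl carbon gives a 2.0-fold lower number from compound 2 to compound 3 (0.30 log units; within the scatter), so the first measured change at this position does not separate the two groups. The loss of the hydrogen-bond donor of 2-carboxyethyl and the entry of a five-membered aromatic ring therefore leave no reading beyond the scatter on this read-out. Nothing measured here bears on a cause for this step.

As far as these compounds go, it remains open whether an amine or a longer chain on the same carbonyl carbon would shift the value beyond the scatter. A phenyl ring in place of furan-2-yl also remains untested among the compounds shown.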